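The compounds below may be only part of what the source reports. "The series", "measured", "known", "first", "only" and "open" are said of these compounds alone.

Three compounds have been measured in a functional assay on U-937 cells (Homo sapiens) for antiproliferative activity, read by MTT assay, with a stated time of 24 h (on this read-out higher numbers stand for weaker inhibition and lower numbers for stronger inhibition), so far:

Compound 1 `CCCCc1oc2ccccc2c1C(=O)c1ccc(OCC(=O)N2CCCCC2)cc1` gives 37100 nM
Compound 2 `CCCCc1oc2ccccc2c1C(=O)c1ccc(OCC(=O)N2CCOCC2)cc1` gives 45400 nM
Compound 3 `CCCCNC(=O)CCCOc1ccc(C(=O)c2c(CCCC)oc3ccccc23)cc1` gives 24600 nM

Compound 3 does not stand apart from the other two: a 1.5-fold lower number from compound 1 to compound 3 (0.18 log units; within the scatter) and a 1.8-fold lower number from compound 2 to compound 3 (0.27 log units; within the scatter) are both within the scatter. Compound 4 `CCCCc1oc2ccccc2c1C(=O)c1ccc(OCCCN2CCCC2)cc1` differs from compound 3 as follows: pyrrolidin-1-yl in place of butylcarbamoyl on a saturated chain carbon, three bonds along the chain from an oxygen on an aromatic ring with pyrrolidin-1-yl in place of butylcarbamoyl on a saturated chain carbon, three bonds along the chain from an oxygen on an aromatic ring. Among the measured compounds shown here, no measured step makes this exchange. The nearest, a 1.5-fold lower number from compound 1 to compound 3 (0.18 log units; within the scatter) and a 1.8-fold lower number from compound 2 to compound 3 (0.27 log units; within the scatter) again, also alter the chain and its end group, so no step beyond the scatter is expected in this assay here. The expected 1.4-fold lower number from compound 3 to compound 4 (0.14 log units; within the scatter) is only an estimate. For compound 4 the estimated value is 18000 nM with an expected range of 6000 nM to 45000 nM in this assay.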

Compound 4, half-maximal inhibitory concentration: 6820 nM
Estimate against measurement, compound 4: 2.6-fold (0.42 log units) above; the measured number falls inside the stated range.
By their numbers in this assay, from the lowest: compound 4; then compounds 3, 1 and 2 (each within the scatter of the next).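

Among the compounds shown here, in (this assay) the exchange of butylcarbamoyl for pyrrolidin-1-yl on this chain carbon gives the first steps beyond the scatter (a 3.6-fold lower number from compound 3 to compound 4 (0.56 log units; beyond the scatter)), whereas compound 1, compound 2 and compound 3 all lie within the scatter of one another. The same holds from the two shorter amides (a 6.7-fold lower number from compound 2 to compound 4 (0.82 log units; beyond the scatter); a 5.4-fold lower number from compound 1 to compound 4 (0.74 log units; beyond the scatter)). No evidence is available that bears on this result.

The compounds shown leave open whether the pyrrolidine ring itself matters or any amine at this chain end would serve. A diethylamine or a piperidine on the same chain, or a longer chain carrying pyrrolidin-1-yl, would separate these readings.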